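The source may hold more compounds than are shown below. What is called first, only, known or untested is meant among the compounds shown, and "the series" means these compounds.

Among the measured compounds shown here, compound 1 `CC(C)C(=O)NC1CCN(c2ccc3cc(NC(=O)CCc4ccc(C(F)(F)F)cc4)ccc3n2)C1` gives 1 nM in an assay on isolated protein for displacement of a labelled ligand from melanin-concentrating hormone receptor 1 (Homo sapiens) (a higher number here means a weaker inhibitor, a lower number a stronger inhibitor), the lowest of the three numbers known so far. Compound 2 `O=C(CCCCCCCCCCCCc1ccc(C(F)(F)F)cc1)Nc1ccc2nc([N+]34CCC(CC3)CC4)ccc2c1` gives 5 nM in this assay, and compound 3 `CCCc1cc(N(C)C)c2cc(NC(=O)CCc3ccc(C(F)(F)F)cc3)ccc2n1` gives 12 nM; both stand beyond the usual scatter above compound 1. Compound 4 `O=C(CCc1ccc(C(F)(F)F)cc1)Nc1ccc2nc(N3CC4CCC3C4)ccc2c1` has not yet been measured. It differs from compound 1 in one place: a group of 7 heavy atoms (6 carbon, 1 nitrogen; one five-membered non-aromatic ring of carbon only, one five-membered non-aromatic ring with 1 hetero atom) in place of a group of 11 heavy atoms (8 carbon, 2 nitrogen, 1 oxygen; one five-membered non-aromatic ring with 1 hetero atom), on an aromatic carbon. For the measured compounds named here, no measured pair shows exactly this change, so the expected step of a 7.0-fold higher number from compound 1 to compound 4 (0.85 log units; beyond the scatter) rests on the wider set: a moderate rise is expected, because compound 2 gives 5 nM and compound 3 gives 12 nM while both carry an amine without the amide found in compound 1. For compound 4 the estimate is 7 nM, with a likely range from 2 nM to 30 nM.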

Compound 4, half-maximal inhibitory concentration: 1 nM
Beside the measured number, compound 4's estimate is 7.0-fold (0.85 log units) above it, and the stated range ends above it.
By their numbers in this assay, from the lowest: compounds 1 and 4 (each within the scatter of the next); then compound 2; then compound 3.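

At this position, on an aromatic carbon next to the ring nitrogen, replacing the 3-((isopropylcarbonyl)amino)pyrrolidin-1-yl group with the two-ring amine of 7 heavy atoms gives no change at the digits printed from compound 1 to compound 4 (within the scatter) in this assay. The amide carbonyl and the hydrogen-bond donor of compound 1 can therefore be lost here without a measurable change, and the number stays as low with the smaller group. Nothing measured here gives a reason for this. As far as these compounds go, it remains open whether a simple piperidine, a morpholine or a carboxylic acid at this position would hold the number as low.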